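The source may report more compounds than this note shows. Statements on the series, on what has been measured and on what is new or still open speak of the compounds shown alone.

Compound 1 `CC1CCN(C2CCN(S(=O)(=O)c3cn(C)cn3)CC2)CC1`, compound 2 `CCc1ccc(S(=O)(=O)N2CCC(N3CCC(C)CC3)CC2)cc1`, compound 3 `CC1CCN(C2CCN(S(=O)(=O)c3ccc(F)cc3F)CC2)CC1`.

In a functional assay on DLD-1 cells (Homo sapiens) for antiproliferative activity, read by CellTiter-Glo, with a stated time of 72 h (a higher number here means a weaker inhibitor, a lower number a stronger inhibitor), compound 1 reaches only a limit of the assay, > 5000 nM. Compound 2 likewise gives only a limit, > 5000 nM. Among the measured compounds shown here, compound 3 is the single compound with a number, 102 nM, and so stands alone as the one readable point. The step that the two limits leave unreadable from compound 1 to compound 2 stays unreadable because of the limit of > 5000 nM in this assay, at which 2 of the 3 values shown sit. By contrast an at least 49-fold lower number from compound 1 to compound 3 (1.69 log units; beyond the scatter) and an at least 49-fold lower number from compound 2 to compound 3 (1.69 log units; beyond the scatter) are both large. Compound 4 `CC1CCN(C2CCN(S(=O)(=O)c3cccnc3Cl)CC2)CC1` differs from compound 3 by 2-chloropyridin-3-yl in place of 2,4-difluorophenyl on a sulfonyl sulfur. Only those two large steps bear on this change; they show that the ring on the sulfonyl sulfur matters greatly among these compounds. Compound 4 is expected to be somewhat weaker, a 2.9-fold higher number from compound 3 to compound 4 (0.47 log units; beyond the scatter). The estimate for compound 4 is 300 nM, between 60 nM and 3000 nM.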

Compound 4, half-maximal inhibitory concentration: > 5000 nM
Compound 4: no number, only a limit; the forecaster's own chance of this, stated with the estimate: 25%; middle value at least 16-fold (1.22 log units) from the limit.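

In this assay the change on the sulfonyl sulfur gives an at least 49-fold higher number from compound 3 to compound 4 (1.69 log units; beyond the scatter), so a halogen on the aromatic ring does not by itself carry the activity. Among the four compounds only the 2,4-difluorophenyl group gives a readable number, whereas the earlier failures carried no halogen. The steps from compound 1 and compound 2 to compound 4 cannot be read, because both ends of each are limits: the limit of > 5000 nM in this assay, at which 3 of the 4 values shown sit.

The compounds shown do not separate the ring nitrogen from the chlorine as the source of the loss. On these data alone, how a plain phenyl or a chlorophenyl group on the sulfonyl sulfur would read stays open.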